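Working notes: compound 4 against the measured series

The compounds below may be only part of what the source reports. "The series", "measured", "known", "first", "only" and "open" are said of these compounds alone.

The shared core of compound 1 `Cc1c(C(=O)CSCCN)[n+]([O-])c2ccccc2[n+]1[O-]` carries an aminoethyl thioether side chain; in an ADME assay on Vero cells (Chlorocebus sabaeus) for cytotoxicity, read by MTT assay, with a stated time of 72 h (a higher number here means that more compound is tolerated, a lower number that less compound is tolerated), compound 1 has no reported result, "not determined" (no result reported). Compound 2 `Cc1c(C(=O)CSCCNC(=O)c2ccccc2)[n+]([O-])c2ccccc2[n+]1[O-]` acylates that amine with a phenyl carbonyl. In this assay compound 2 gives only a limit of the assay, > 100 ug/mL. Compound 3 `COc1ccc(C(=O)NCCSCC(=O)c2c(C)[n+]([O-])c3ccccc3[n+]2[O-])cc1` adds methoxy in place of hydrogen on an aromatic carbon. In this assay compound 3 likewise gives only a limit, > 100 ug/mL. The step that the two limits leave unreadable from compound 2 to compound 3 cannot be sized, since both ends are limits. Compound 3 therefore stands at the limit of > 100 ug/mL in this assay, at which 2 of the 3 values shown sit.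

Compound 4 `Cc1c(C(=O)CSCCNC(=O)c2cccs2)[n+]([O-])c2ccccc2[n+]1[O-]` differs from compound 3 by thiophen-2-yl in place of 4-methoxyphenyl on a carbonyl carbon. For the measured compounds named here, no measured step bears on an aromatic ring swap at the amide carbonyl; the single measured step is unreadable. Nothing in the series indicates a shift beyond the scatter, so the step that the limit leaves unreadable from compound 3 to compound 4 is expected to be small. Compound 4 is expected to give 150 ug/mL, in the range 60 ug/mL to 400 ug/mL, most probably reported again only as a limit.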

Compound 4, half-maximal cytotoxic concentration: > 100 ug/mL
Compound 4: only a limit was reported (the forecaster's own chance of this, stated with the estimate: 80%); the middle value is on the limit's open side.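

No step can be read for compound 4 against compound 2 or compound 3, since all three are reported only as limits in this assay: the limit of > 100 ug/mL in this assay, at which 3 of the 4 values shown sit.

The compounds shown leave open whether thiophen-2-yl, phenyl or 4-methoxyphenyl on the carbonyl carbon makes any difference in this assay.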